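Aminophenyl Ketone Weighed Against a Limit-Bound Iodophenyl Analogue

The source may hold more compounds than are shown below. What is called first, only, known or untested is meant among the compounds shown, and "the series" means these compounds.

Compound 3 `O=C(/C=C/c1ccc2c(c1)B(O)OC2)c1ccc(I)cc1` returns only a limit in a toxicity assay on WI-38 cells (Homo sapiens) for cytotoxicity, read by MTT assay, with a stated time of 48 h (a lower number here means a stronger inhibitor, a higher number a weaker inhibitor), namely > 100000 nM, not a measured number. Compound 2 `Cn1cccc1C(=O)/C=C/c1ccc2c(c1)B(O)OC2` likewise returns only the limit > 100000 nM. Within the data shown here, compound 1 `O=C(/C=C/c1ccc2c(c1)B(O)OC2)c1ccc(-c2ccccc2)cc1` gives a measured 18300 nM, so the step of an at least 5.4-fold higher number from compound 1 to compound 3 (0.73 log units; beyond the scatter) is the one readable change, running toward weaker inhibition. The step that the two limits leave unreadable from compound 2 to compound 3 cannot be sized; both of its ends sit at the limit of > 100000 nM in this assay, at which 2 of the 3 values shown sit. Compound 4 `Nc1cccc(C(=O)/C=C/c2ccc3c(c2)B(O)OC3)c1` differs from compound 3 by 3-aminophenyl in place of 4-iodophenyl on a carbonyl carbon. Among the measured compounds shown here, no measured step exchanges this ring for an amino-bearing one, so the expectation rests on both limit-bound ketones. Compound 4 is expected to stay near the limit, a step of a number no higher from compound 3 to compound 4 (the limit leaves the size open) of no readable size. Compound 4 is estimated at 100000 nM, between 30000 nM and 300000 nM.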

Compound 4, half-maximal inhibitory concentration: 25300 nM
The estimate for compound 4 lay 4.0-fold (0.60 log units) above the measured number; the measured number lies below the stated range.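

On the carbonyl carbon, 3-aminophenyl gives an at least 3.9-fold lower number from compound 3 to compound 4 (0.59 log units; beyond the scatter) and an at least 3.9-fold lower number from compound 2 to compound 4 (0.59 log units; beyond the scatter) in this assay. A ring without the phenyl substituent of compound 1 can therefore also give a measured number here, while 4-iodophenyl and 1-methyl-1H-pyrrol-2-yl do not. Both steps have an open size because each starts from a limit: the limit of > 100000 nM in this assay, at which 2 of the 4 values shown sit.

The compounds shown leave open whether the amine or its ring position accounts for the step. A 4-aminophenyl, 3-hydroxyphenyl or 3-iodophenyl ring on the same carbonyl carbon would separate these readings.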